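From compound 3 to a halogenated aromatic end group

A few compounds are considered here, and "the series" means these few. Any claim that something is new, unique, unknown or untested is made for them only; others in the source may bear on it.

In a functional assay on NCI-H460 cells (Homo sapiens) for inhibition, read by MTT assay, with a stated time of 4 days (a higher number here means a weaker inhibitor, a lower number a stronger inhibitor), compound 1 (`COc1cc(NC(C)CCCNC(=O)NNC(=O)NCCCCCO)c2ncccc2c1`) gives > 100000 nM, which is a limit. Compound 2 (`COc1cc(NC(C)CCCNC(=O)NNC(=O)NC(CO)(CO)CO)c2ncccc2c1`) gives > 100000 nM, also a limit. Compound 3 (`COc1cc(NC(C)CCCNC(=O)NNC(=O)N(CCO)CCO)c2ncccc2c1`) gives > 100000 nM, again a limit, so it stands without a number. The measured steps, a step that the two limits leave unreadable from compound 1 to compound 2, a step that the two limits leave unreadable from compound 1 to compound 3 and a step that the two limits leave unreadable from compound 2 to compound 3, have no readable size, and all three compounds share (the limit of > 100000 nM in this assay, at which 3 of the 3 values shown sit).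

Compound 4 (`COc1cc(NC(C)CCCNC(=O)Nc2ccc(Cl)c(C(F)(F)F)c2)c2ncccc2c1`) carries 4-chloro-3-(trifluoromethyl)phenyl in place of (bis(2-hydroxyethyl)carbamoyl)amino on an amide-type nitrogen. For the measured compounds named here, no measured step covers this change, so its size is a judgement. In this assay, the expected change is an at least 10-fold lower number from compound 3 to compound 4 (1.00 log units; beyond the scatter), toward a stronger inhibitor. Compound 4 is estimated at 10000 nM, with an expected range of 2000 nM to 60000 nM.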

Compound 4, half-maximal inhibitory concentration: 28000 nM
Compound 4: middle estimate off by 2.8-fold (0.45 log units), on the low side; measured number inside the range.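

For the compounds shown here, compound 4 is the first compound here to give a number in this assay, so the group on this amide-type nitrogen can shift the read-out (an at least 3.5-fold lower number from compound 3 to compound 4 (0.55 log units; beyond the scatter); an at least 3.5-fold lower number from compound 2 to compound 4 (0.55 log units; beyond the scatter); an at least 3.5-fold lower number from compound 1 to compound 4 (0.55 log units; beyond the scatter)). From the compounds shown here alone, each step starts from a limit, so its true size stays unknown. The three carbamoyl-amino end groups could not be told apart, whereas 4-chloro-3-(trifluoromethyl)phenyl separates from them: (the limit of > 100000 nM in this assay, at which 3 of the 4 values shown sit).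

The compounds shown leave open whether the chlorine, the trifluoromethyl or the phenyl ring itself carries this step. A plain phenyl, a 4-chlorophenyl or a pyridine ring at this nitrogen would begin to settle that.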